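From Phenylethenyl to Dimethoxyphenyl on the Saturated Ring Carbon

The source may report more compounds than this note shows. Statements on the series, on what has been measured and on what is new or still open speak of the compounds shown alone.

Compound 2 `Cc1cc(O)c(C2=NN(c3ccc(S(N)(=O)=O)cc3)C(/C=C/c3ccccc3)C2)cc1Cl` stands highest of the two numbers measured in a functional assay on NCI-H23 cells (Homo sapiens) for antiproliferative activity, with a stated time of 48 h (a lower number here means that less compound is tolerated, a higher number that more compound is tolerated), giving 35400 nM. Among the compounds with values here, its only neighbour, compound 1 `Cc1cc(O)c(C2=NN(c3ccc(S(N)(=O)=O)cc3)C(c3ccccc3Cl)C2)cc1Cl`, gives 7130 nM in this assay, and the single step between them, a 5.0-fold higher number from compound 1 to compound 2 (0.70 log units; beyond the scatter), lies beyond the scatter. Compound 3 `COc1ccc(C2CC(c3cc(Cl)c(C)cc3O)=NN2c2ccc(S(N)(=O)=O)cc2)cc1OC` has not yet been measured in this assay; it differs from compound 2 by 3,4-dimethoxyphenyl in place of 2-phenylethenyl on a saturated ring carbon. The step from compound 1 to compound 2 is the only one that bears on this change: it shows that an aromatic ring on the saturated ring carbon is tolerated less than the phenylethenyl arm, and compound 3 brings such a ring back. A lower number is therefore expected for compound 3, of roughly the size seen in that step, estimated at 10000 nM with a range from 3000 nM to 35000 nM, which means an expected step of a 3.5-fold lower number from compound 2 to compound 3 (0.55 log units; beyond the scatter).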

Compound 3, concentration lethal to 50% of the cells: > 100000 nM
Compound 3: no number, only a limit; the forecaster's own chance of this, stated with the estimate: 5%; at least 10-fold (1.00 log units) between middle value and limit.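

Compound 3 gives no number in this assay, only a limit: the limit of > 100000 nM in this assay, at which 1 of the 3 values shown sits.

Putting 3,4-dimethoxyphenyl in place of 2-phenylethenyl on this saturated ring carbon gives an at least 2.8-fold higher number from compound 2 to compound 3 (0.45 log units; beyond the scatter), so an aromatic ring at this place does not by itself bring the number down. The two aromatic groups seen here, 2-chlorophenyl and 3,4-dimethoxyphenyl, stand apart by an at least 14-fold higher number from compound 1 to compound 3 (1.14 log units; beyond the scatter), so what the ring carries matters at this position, not only whether a ring is present.

The compounds shown leave open whether a plain phenyl or a 3-methoxyphenyl group on this carbon would sit closer to compound 1 or to compound 3. Going by these compounds, the full size of both new steps also stays open.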